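Fluoro in Place of Methyl: Expected Solubility of Compound 3

The source may report more compounds than this note shows. Statements on the series, on what has been measured and on what is new or still open speak of the compounds shown alone.

Compound 2 `COC(=O)CC[C@H](NC(=O)c1ccc(N(C)Cc2cnc3nc(N)nc(NC(=O)OCc4ccc(B(O)O)c(C)c4)c3n2)cc1)C(=O)OC` and compound 1 `COC(=O)CC[C@H](NC(=O)c1ccc(N(C)Cc2cnc3nc(N)nc(NC(=O)OCc4ccc(B(O)O)cc4)c3n2)cc1)C(=O)OC` share one core and differ only in a methyl in place of hydrogen on an aromatic carbon. In a physicochemical assay for solubility, read by HPLC, in phosphate buffer, measured as kinetic solubility, with a stated time of 20 h (on this read-out lower numbers stand for lower solubility and higher numbers for higher solubility), compound 1 gives 3000 nM, and compound 2 gives 3100 nM. Among the measured compounds shown here, the step of a 1.0-fold higher number from compound 1 to compound 2 (0.01 log units; within the scatter) shows that these two numbers cannot be told apart, so compound 2 stands level with compound 1 on the numbers known so far. Compound 3 `COC(=O)CC[C@H](NC(=O)c1ccc(N(C)Cc2cnc3nc(N)nc(NC(=O)OCc4ccc(B(O)O)c(F)c4)c3n2)cc1)C(=O)OC` is the next step: fluoro in place of methyl on an aromatic carbon. For the measured compounds named here, only the step from compound 1 to compound 2 bears on this change, and that step was within the scatter, so a single small group exchanged at the same place is expected to leave the number essentially unchanged; the expected step is a 1.0-fold lower number from compound 2 to compound 3 (0.01 log units; within the scatter). Compound 3 is therefore estimated at 3000 nM, with a range from 1500 nM to 6000 nM.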

Compound 3, solubility: 4600 nM
Compound 3: the middle estimate sits 1.5-fold (0.19 log units) below what was measured, and the stated range covers the measured number.
By their numbers in this assay, from the lowest: compounds 1, 2 and 3 (each within the scatter of the next).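

In this assay the aromatic carbon ortho to a group of 3 heavy atoms has now carried hydrogen, methyl and fluoro, and the three numbers cannot be told apart. Fluoro in place of methyl gives one new step (a 1.5-fold higher number from compound 2 to compound 3 (0.17 log units; within the scatter)) and fluoro in place of hydrogen gives another (a 1.5-fold higher number from compound 1 to compound 3 (0.19 log units; within the scatter)), so the exchange of one heavy atom for another, like the earlier exchange of hydrogen for methyl, stays within the usual spread of repeated measurements. Nothing available explains the small differences that are seen.

The compounds shown leave open whether a group such as an amine, a carboxylic acid or a longer chain at this carbon would move the number beyond that spread. They also leave open whether fluoro or methyl would behave alike on other carbons of this ring.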